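Swapping the Linker Arm on a Shared Core

The compounds below may be only part of what the source reports. "The series", "measured", "known", "first", "only" and "open" are said of these compounds alone.

Compound 1 `COc1ccc(C(=O)/C=C/c2cc(-c3cc(OC)c(OC)c(OC)c3)n3nc(-c4ccccc4)cc3n2)cc1` gives 25200 nM in a functional assay on DU-145 cells (Homo sapiens) for antiproliferative activity, read by MTT assay, with a stated time of 24 h (on this read-out lower numbers stand for stronger inhibition and higher numbers for weaker inhibition), the lower of the two numbers shown, though its gap to compound 2 lies within the scatter. Compound 2 `COc1cc(C(=O)/C=C/c2cc(-c3cc(OC)c(OC)c(OC)c3)n3nc(-c4ccccc4)cc3n2)cc(OC)c1OC` gives 34900 nM in this assay, and the step of a 1.4-fold higher number from compound 1 to compound 2 (0.14 log units; within the scatter) is within the scatter. Compound 3 `COc1cc(-c2cc(C(=O)/C=C/c3ccc(Cl)cc3)nc3cc(-c4ccccc4)nn23)cc(OC)c1OC` carries (2-(4-chlorophenyl)ethenyl)carbonyl in place of 2-((4-methoxyphenyl)carbonyl)ethenyl on an aromatic carbon. No measured step bears on this change; the single step shown concerns a different part of the molecule and stayed within the scatter. No shift beyond the scatter is therefore expected, a 1.1-fold lower number from compound 1 to compound 3 (0.06 log units; within the scatter). Compound 3 is estimated at 22000 nM in this assay, with a range from 6000 nM to 70000 nM.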

Compound 3, half-maximal inhibitory concentration: 19500 nM
For compound 3 the middle estimate is 1.1-fold (0.05 log units) above the measured one; the measured number falls inside the stated range.
By their numbers in this assay, from the lowest: compounds 3, 1 and 2 (each within the scatter of the next).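

Compounds 1 and 2 differ only in the ring on the carbonyl, whereas compound 3 exchanges the whole arm on the aromatic carbon next to the ring nitrogen. In this assay, placing (2-(4-chlorophenyl)ethenyl)carbonyl there gives a 1.3-fold lower number from compound 1 to compound 3 (0.11 log units; within the scatter), so this exchange of arms leaves the numbers within the scatter. Nothing available explains this result.

Going by these compounds alone, the single step cannot separate the reversed arm from the chlorine on its ring. As far as these compounds go, how an amine or a carboxylic acid on that ring, or a longer chain in the arm, would read remains open.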